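Toward a larger aromatic group on compound 3

The source may hold more compounds than are shown below. What is called first, only, known or untested is meant among the compounds shown, and "the series" means these compounds.

Compound 1, `C#CCNCC(O)COc1ccc2c(C)c(Cc3ccccc3)c(=O)oc2c1`: 95500 nM in an ADME assay on A549 cells (Homo sapiens) for cytotoxicity, read by CellTiter-Glo; a lower number here means that less compound is tolerated, a higher number that more compound is tolerated
Compound 2, `Cc1c(Cc2ccccc2)c(=O)oc2cc(OCC(O)CNc3nccs3)ccc12`: 93000 nM
Compound 3, `Cc1c(Cc2ccc(F)cc2)c(=O)oc2cc(OCC(O)CN3CCC(C(N)=O)CC3)ccc12`: 89300 nM

Of the compounds shown here, three built on a shared core have been measured so far, and their numbers in this assay sit close together. Among the measured compounds shown here, the one step between compounds that differ in a single place, a 1.0-fold lower number from compound 1 to compound 2 (0.01 log units; within the scatter), replaced propargyl with 1,3-thiazol-2-yl on an amine nitrogen and stayed within the scatter. Compound 3 gives the lowest of the three numbers, but its gap to compound 2 and to compound 1 is also within the scatter, so no order among the three can be read from these values.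

Compound 4, `Cc1c(Cc2ccc(-c3ccc(C#N)c(F)c3)cc2)c(=O)oc2cc(OCC(O)CN3CCC(C(N)=O)CC3)ccc12`, is the next compound to be measured. It differs from compound 3 in this way: 4-cyano-3-fluorophenyl in place of fluoro on an aromatic carbon. For the measured compounds named here, the group that enters brings nine heavy atoms and a six-membered aromatic ring with a nitrile, at a place on the core where none of the measured compounds has been varied. Going by the values given here, the only measured step, a 1.0-fold lower number from compound 1 to compound 2 (0.01 log units; within the scatter), concerns a different part of the molecule and was within the scatter, so it neither supports nor argues against a change here. Among the compounds with values here, with no direct precedent, compound 4 is estimated at 60000 nM, within 20000 nM to 100000 nM. This estimate means a step of a 1.5-fold lower number from compound 3 to compound 4 (0.17 log units; within the scatter), leaning toward a lower number but with a range wide enough to include no step beyond the scatter.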

Compound 4, half-maximal cytotoxic concentration: 29100 nM
Compound 4: middle estimate off by 2.1-fold (0.31 log units), on the high side, within the range that was stated.
By their numbers in this assay, from the lowest: compound 4; then compounds 3, 2 and 1 (each within the scatter of the next).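

In this assay, the aromatic carbon that carries fluoro in compound 3 turns out to be a place where a change can move the number beyond the scatter: 4-cyano-3-fluorophenyl there gives the step (a 3.1-fold lower number from compound 3 to compound 4 (0.49 log units; beyond the scatter)). The earlier compounds all sat within the scatter of one another, so this is the only step among those shown that reads as a difference, and it runs toward less compound being tolerated, although it is modest in size. The change replaces one heavy atom with nine and brings in a six-membered aromatic ring and a nitrile together, and no measurement is at hand that would explain the step or assign it to any part of the entering group.

The compounds shown leave open whether a plain phenyl, or a nitrile alone, in place of fluoro would give a step of similar size. They also leave open whether 4-cyano-3-fluorophenyl would give a like step on compounds carrying the propargyl amine of compound 1 or the 1,3-thiazol-2-yl amine of compound 2.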